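The compounds below may be only part of what the source reports. "The series", "measured", "known", "first", "only" and "open" are said of these compounds alone.

Among the measured compounds shown here, in a functional assay on ACHN cells (Homo sapiens) (on this read-out higher numbers stand for weaker inhibition of growth and lower numbers for stronger inhibition of growth), compound 1 `O=S(=O)(/C=C/c1ccc(F)cc1)Cc1ccc(Nc2ncnc3ccccc23)cc1` gives 10 nM, while compound 2 `O=S(=O)(/C=C/c1ccc(F)cc1Cl)Cc1ccc(Nc2ncnc3ccccc23)cc1` gives 73000 nM, the highest of the two numbers and far from its only neighbour. For the measured compounds named here, the single measured change, a 7300-fold higher number from compound 1 to compound 2 (3.86 log units; beyond the scatter), was a large one, yet it concerns a different ring from the one altered next. Compound 3 `O=S(=O)(/C=C/c1ccc(F)cc1Cl)Cc1ccc(Nc2ncnc3cc(Cl)ccc23)cc1` differs from compound 2 by chloro in place of hydrogen on an aromatic carbon. Going by the values given here, no measured step touches this place on the shared core, so a step within the scatter is expected: a 1.2-fold lower number from compound 2 to compound 3 (0.09 log units; within the scatter). Compound 3 is therefore estimated at 60000 nM, within the range 15000 nM to 250000 nM.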

Compound 3, concentration for 50% growth inhibition: 17000 nM
For compound 3 the middle estimate is 3.5-fold (0.55 log units) above the measured one; low and high end bracket the measured number.
By their numbers in this assay, from the lowest: compound 1; then compound 3; then compound 2.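

In this assay, chloro in place of hydrogen on an aromatic carbon of the fused system of two rings gives a 4.3-fold lower number from compound 2 to compound 3 (0.63 log units; beyond the scatter), so this position on the shared core does respond to substitution. The same replacement on the other ring moved the number the opposite way, with a 7300-fold higher number from compound 1 to compound 2 (3.86 log units; beyond the scatter), so its effect here depends on where it sits. Nothing available explains this shift.

Still open, on these data alone, is whether an amine or a methoxy group at this position would move the number further, and whether chloro here would have the same effect without the chloro on the other ring.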